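Working notes: bromo on the compound 2 chain

A few compounds are considered here, and "the series" means these few. Any claim that something is new, unique, unknown or untested is made for them only; others in the source may bear on it.

Measured so far in a functional assay on HL-60 cells (Homo sapiens) for cytotoxicity, read by MTT assay, with a stated time of 72 h; a lower number here means a stronger inhibitor, a higher number a weaker inhibitor:
- compound 1 `CCCCCCCCCCCCCC(O)C1OC(=O)c2c(OC)cccc21` gives 21 ug/mL
- compound 2 `CCCCCCCCCCCCCCCc1cccc(OC)c1C(=O)OC` gives > 25 ug/mL (a limit)

Not yet measured: compound 3 `CCCCCCCCCCCCCCC(Br)c1cccc(OC)c1C(=O)OC`.

Compound 2 has no numeric reading. In this assay compound 2 stands at > 25 ug/mL, which is a limit and not a number. The record so far shows (the limit of > 25 ug/mL in this assay, at which 1 of the 2 values shown sits). Within the data shown here, the only numeric value comes from compound 1, at 21 ug/mL.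

Compound 3 differs from compound 2 in one place: bromo in place of hydrogen on a saturated chain carbon bound to an aromatic carbon and a saturated chain carbon.

Among the measured compounds shown here, no measured step covers this change, so the expectation is loose. In this assay no step beyond the usual scatter is expected, and no direction is favoured. The scale for this expectation comes from compound 1 at 21 ug/mL. The expected change is an at least 1.1-fold lower number from compound 2 to compound 3 (0.05 log units; that floor lies within the scatter). For compound 3 the estimated value is 22 ug/mL, with an expected range of 9 ug/mL to 45 ug/mL.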

Compound 3, half-maximal inhibitory concentration: > 25 ug/mL
Compound 3 ended at the assay's limit; the forecaster's own chance of this, stated with the estimate: 50%; at least 1.1-fold (0.05 log units) between middle value and limit.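

In this assay, compound 2 and compound 3 both stand at a limit and not at a number, so no step can be read between them: the limit of > 25 ug/mL in this assay, at which 2 of the 3 values shown sit.

The compounds shown leave open whether bromo in place of hydrogen on a saturated chain carbon bound to an aromatic carbon and a saturated chain carbon changes the reading at all, and in which direction.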